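Three hydroxyphenyl isomers on one shared core

The source may hold more compounds than are shown below. What is called first, only, known or untested is meant among the compounds shown, and "the series" means these compounds.

Measured so far:
compound 1, `Oc1ccc(-c2cc(-c3ccccc3O)cc(-c3cccc(O)c3)n2)cc1`, 4850 nM
compound 2, `Oc1cccc(-c2cc(-c3ccccc3O)nc(-c3ccccc3O)c2)c1`, 5020 nM
compound 3, `Oc1ccccc1-c1cc(-c2ccccc2O)nc(-c2ccccc2O)c1`, 2180 nM

In a functional assay on HCT-15 cells (Homo sapiens) for cytotoxicity, read by CCK-8 assay, with a stated time of 4 days (a higher number here means a weaker inhibitor, a lower number a stronger inhibitor), compound 3 gives the lowest of the three numbers. Its nearest neighbour is compound 1, and compound 2 sits furthest away. Within the data shown here, the one single-point step on record, a 2.3-fold lower number from compound 2 to compound 3 (0.36 log units; beyond the scatter), exchanges a 3-hydroxyphenyl for a 2-hydroxyphenyl on the shared core and is modest but beyond the scatter. Compounds 1 and 2 differ in more than one place, so their two values can only be set side by side; they lie within the scatter of each other.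

Compound 4, `Oc1ccc(-c2cc(-c3ccccc3O)cc(-c3ccccc3O)n2)cc1`, is the next compound. Relative to compound 3 the change is 4-hydroxyphenyl in place of 2-hydroxyphenyl on an aromatic carbon. Among the measured compounds shown here, no measured step covers exactly this exchange. For the measured compounds named here, the only guide is that in the step from compound 2 to compound 3 the 2-hydroxyphenyl gave the lower number, and that compound 1, which carries a 4-hydroxyphenyl at this very position, sits above compound 3. A modest rise is therefore expected, a 2.1-fold higher number from compound 3 to compound 4 (0.31 log units; beyond the scatter). Compound 4 is estimated at 4500 nM, with a range from 2000 nM to 10000 nM.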

Compound 4, half-maximal inhibitory concentration: 8240 nM
The estimate for compound 4 lay 1.8-fold (0.26 log units) below the measured number, and the stated range covers the measured number.
By their numbers in this assay, from the lowest: compound 3; then compounds 1, 2 and 4 (each within the scatter of the next).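

In this assay, among these compounds, placing 4-hydroxyphenyl instead of 2-hydroxyphenyl on the carbon next to the ring nitrogen gives a 3.8-fold higher number from compound 3 to compound 4 (0.58 log units; beyond the scatter), the first direct reading of this exchange, and it favours the 2-hydroxyphenyl group at this position on this core. The earlier exchange of 3-hydroxyphenyl for 2-hydroxyphenyl, by contrast, does not repeat its lowering of the number when the partner groups differ, since on the core of compound 1 it gives a 1.7-fold higher number from compound 1 to compound 4 (0.23 log units; within the scatter), which cannot be told apart from no change. A benefit from 2-hydroxyphenyl is therefore not a fixed property of this exchange, and it depends on the rest of the molecule, as the two readings of the same change show: the same change on two cores in this assay, a 2.3-fold lower number (0.36 log units; beyond the scatter) from compound 2 to compound 3 and a 1.7-fold higher number (0.23 log units; within the scatter) from compound 1 to compound 4, 3.9-fold (0.59 log units) apart, beyond the scatter of two such steps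

The compounds shown carry only hydroxyphenyl isomers, so they leave open whether a methoxyphenyl, an aminophenyl or a plain phenyl at this position would hold the number near that of compound 3, at 2180 nM. Among the compounds shown here, they also leave open why the same exchange reads differently on the two cores, as only one pair of steps bears on that question.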